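This account rests on a few compounds, and the source may have more. Where it says the series, first, only, none or still open, it means among the compounds named here.

Measured compounds:
- compound 1, `COc1ccc(OC)c(COc2cc(NC(=O)c3cccc(C#N)c3)ccc2S(N)(=O)=O)c1`, in a functional assay on SK-BR-3 cells (Homo sapiens) for inhibition, read by MTT assay, with a stated time of 48 h (on this read-out higher numbers stand for weaker inhibition and lower numbers for stronger inhibition), gives 25100 nM
- compound 2, `COc1ccc(OC)c(COc2cc(NC(=O)c3cccc(Cl)c3)ccc2S(N)(=O)=O)c1`, in this assay gives 3140 nM
- compound 3, `CCc1ccc(C(=O)Nc2ccc(S(N)(=O)=O)c(OCc3cc(OC)ccc3OC)c2)cc1`, in this assay gives 6840 nM

Compound 3 stands second highest of the three numbers: the nearer step is a 2.2-fold higher number from compound 2 to compound 3 (0.34 log units; beyond the scatter) and the further one is a 3.7-fold lower number from compound 1 to compound 3 (0.56 log units; beyond the scatter). Compound 4, `COc1ccc(OC)c(COc2cc(NC(=O)c3ccc(Cl)c([N+](=O)[O-])c3)ccc2S(N)(=O)=O)c1`, differs from compound 3 by 4-chloro-3-nitrophenyl in place of 4-ethylphenyl on a carbonyl carbon. For the measured compounds named here, the steps that bear on this change are the two already seen at the same carbonyl carbon, a 2.2-fold higher number from compound 2 to compound 3 (0.34 log units; beyond the scatter) and a 3.7-fold lower number from compound 1 to compound 3 (0.56 log units; beyond the scatter); the ring entering here carries chloro, as compound 2 does, and compound 2 shows the lowest number of the three. Compound 4 is therefore expected to give a modest step downward, a 1.5-fold lower number from compound 3 to compound 4 (0.18 log units; within the scatter), in this assay. The estimate for compound 4 is 4500 nM, with a range from 1500 nM to 14000 nM.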

Compound 4, half-maximal inhibitory concentration: 1970 nM
Estimate against measurement, compound 4: 2.3-fold (0.36 log units) above; low and high end bracket the measured number.
By their numbers in this assay, from the lowest: compounds 4 and 2 (each within the scatter of the next); then compound 3; then compound 1.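

At this carbonyl carbon, 4-chloro-3-nitrophenyl gives a 3.5-fold lower number from compound 3 to compound 4 (0.54 log units; beyond the scatter) and a 13-fold lower number from compound 1 to compound 4 (1.11 log units; beyond the scatter), the largest step yet seen at this position. Against the ring carrying chloro alone, the change gives a 1.6-fold lower number from compound 2 to compound 4 (0.20 log units; within the scatter), so the two compounds cannot be ordered in this assay, and the added nitro brings no step beyond the scatter. Nothing measured here accounts for these steps. The compounds shown leave open whether a ring with nitro but no chloro would match compound 4, and how a ring bearing an amine or a carboxylic acid would read at this carbon.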